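The compounds below may be only part of what the source reports. "The series", "measured", "known", "first", "only" and "open" are said of these compounds alone.

Three compounds that share the core of compound 1 `COc1cc(-c2cc(/C=C/C(=O)c3ccc(N)cc3)[nH]n2)cc(OC)c1OC` have been measured in a functional assay on RPMI-8226 cells (Homo sapiens) for cytotoxicity, read by sulforhodamine B assay, with a stated time of 48 h, tested at 0.1 uM; on this read-out higher numbers stand for a weaker effect at the one concentration tested and lower numbers for a stronger effect. Compound 1 gives 97%. Compound 2 `COc1ccc(C(=O)/C=C/c2cc(-c3cc(OC)c(OC)c(OC)c3)n[nH]2)cc1OC` gives 79% in this assay, and compound 3 `COc1ccc(C(=O)/C=C/c2cc(-c3cc(OC)c(OC)c(OC)c3)n[nH]2)cc1` gives 90%. Compound 3 therefore stands second highest of the three numbers: it lies closest to compound 1, the difference being a number 7 percentage points lower from compound 1 to compound 3 (within the scatter), and furthest from compound 2, the separation being a number 11 percentage points higher from compound 2 to compound 3 (beyond the scatter).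

Compound 4 `COc1cc(-c2cc(/C=C/C(=O)c3ccc(F)c(F)c3)[nH]n2)cc(OC)c1OC` has not yet been measured in this assay. It differs from compound 3 in one place, (3,4-difluorophenyl in place of 4-methoxyphenyl on a carbonyl carbon). Going by the values given here, no measured step involves fluorine, but two steps alter the group on the same carbonyl carbon. The step in which 3,4-dimethoxyphenyl replaced 4-aminophenyl, a number 18 percentage points lower from compound 1 to compound 2 (beyond the scatter), was modest; the step in which hydrogen replaced methoxy, a number 11 percentage points higher from compound 2 to compound 3 (beyond the scatter), was also modest; and a number 7 percentage points lower from compound 1 to compound 3 (within the scatter) stayed within the scatter. Across these three compounds the group on the carbonyl carbon shifts the read-out only modestly in either direction, so a 3,4-difluorophenyl group is expected to do likewise. Compound 4 is therefore expected to give about 85% in this assay, with a range from 68% to 100%, which corresponds to an expected a number 5 percentage points lower from compound 3 to compound 4 (within the scatter), within the scatter.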

Compound 4, a percentage reported as activity, at one concentration (the size of the read-out at that concentration, not a potency): 90%
Estimate against measurement, compound 4: 5 percentage points below; the range from low to high includes it.
By their numbers in this assay, from the lowest: compound 2; then compounds 3, 4 and 1 (each within the scatter of the next).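

In this assay, the only fluorine-bearing group shown on this carbonyl carbon gives a read-out that cannot be told apart from that of the 4-methoxyphenyl group, with no change at the digits printed from compound 3 to compound 4 (within the scatter), even though the hydrogen-bond acceptor counted on the leaving group has no counterpart on the entering one. The other two comparisons place compound 4 as the earlier data placed compound 3: there is a number 11 percentage points higher from compound 2 to compound 4 (beyond the scatter), beyond the scatter, and a number 7 percentage points lower from compound 1 to compound 4 (within the scatter), within it. Going by these compounds alone, the 3,4-dimethoxyphenyl group of compound 2 is thus the only one of the four groups on this carbonyl carbon that stands apart from all the others, while the 4-aminophenyl, 4-methoxyphenyl and 3,4-difluorophenyl groups remain within the scatter of one another at this single concentration.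

The information available offers no explanation for why compound 2 stands apart from the other three compounds. As far as these compounds go, it also remains open how a 4-fluorophenyl or a 4-(trifluoromethyl)phenyl group on the same carbonyl carbon would read, and whether the three compounds that cannot be separated here would stay together at other concentrations.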